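From Propargyl to Benzyl in a Carbamate Series

The source may hold more compounds than are shown below. What is called first, only, known or untested is meant among the compounds shown, and "the series" means these compounds.

Compound 1 `C#CCN1CCCC(OC(=O)Nc2ccccc2)C1` was tested in an assay on BTI-TN-5B1-4 cells for inhibition of Amine oxidase [flavin-containing] B (Homo sapiens), read by fluorescence and Amplex Red, using microsomes, with a stated time of 15 min (on this read-out lower numbers stand for stronger inhibition and higher numbers for weaker inhibition), and gives > 100000 nM, which is a limit of the assay rather than a number (the limit of > 100000 nM in this assay, at which 1 of the 2 values shown sits). Going by the values given here, compound 2 `C#CCN1CCCC(COC(=O)Nc2ccc(C(C)C)cc2)C1` gives 2860 nM in this assay, the only numerical value shown there. Compound 3 `CC(C)c1ccc(NC(=O)OCC2CCCN(Cc3ccccc3)C2)cc1` differs from compound 2 by phenyl in place of ethynyl on a saturated chain carbon bound to an amine nitrogen in a ring. Among the compounds with values here, no measured pair shows this change, so its effect is open. The change is expected to weaken inhibition beyond the usual scatter, by the step of a 5.2-fold higher number from compound 2 to compound 3 (0.72 log units; beyond the scatter). Compound 3 is expected to give 15000 nM, with a range from 2500 nM to 90000 nM.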

Compound 3, half-maximal inhibitory concentration: > 100000 nM
Compound 3 was reported as a limit (the forecaster's own chance of this, stated with the estimate: 20%); middle value at least 6.6-fold (0.82 log units) from the limit.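

Going by these compounds alone, replacing propargyl with benzyl gives an at least 34-fold higher number from compound 2 to compound 3 (1.54 log units; beyond the scatter), the first measured one-place step, and it shows that inhibition at this position is lost when ethynyl gives way to phenyl. Compound 3 gives > 100000 nM in this assay, which is a limit of the assay and not a number, so the true size of the step stays unknown: the limit of > 100000 nM in this assay, at which 2 of the 3 values shown sit.

The compounds shown cannot separate the loss of the triple bond from the arrival of the aromatic ring. An allyl group, with a double bond, or a simple ethyl chain at this position could help tell the two apart.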